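Aryl amide in place of acetyl on a triazene core

The source may hold more compounds than are shown below. What is called first, only, known or untested is meant among the compounds shown, and "the series" means these compounds.

Measured compounds:
compound 1 `O=C(c1cccc(C(F)(F)F)c1)N(/N=N/c1ccc([N+](=O)[O-])cc1Br)c1ccc([N+](=O)[O-])cc1Br`, 1120 nM
compound 2 `CC(=O)N(/N=N/c1ccc([N+](=O)[O-])cc1Cl)c1ccc([N+](=O)[O-])cc1Cl`, 630 nM

In a functional assay on HeLa cells (Homo sapiens) for cytotoxicity, read by MTT assay, with a stated time of 72 h (on this read-out higher numbers stand for weaker inhibition and lower numbers for stronger inhibition), compound 2 gives the lower of the two numbers, but its gap to compound 1 is within the scatter, so the two cannot be ordered. Compound 3 `O=C(c1ccc(C(F)(F)F)cc1)N(/N=N/c1ccc([N+](=O)[O-])cc1Cl)c1ccc([N+](=O)[O-])cc1Cl` differs from compound 2 by a single change: 4-(trifluoromethyl)phenyl in place of methyl on a carbonyl carbon. Compound 1 also carries a trifluoromethyl-substituted aromatic ring on its carbonyl and shows 1120 nM, so little movement is expected. The step of a 1.4-fold higher number from compound 2 to compound 3 (0.15 log units; within the scatter) is expected to stay within the scatter. For compound 3 the estimate is 900 nM, between 350 nM and 2500 nM.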

Compound 3, half-maximal inhibitory concentration: 1060 nM
Beside the measured number, compound 3's estimate is 1.2-fold (0.07 log units) below it; the range from low to high includes it.
By their numbers in this assay, from the lowest: compounds 2, 3 and 1 (each within the scatter of the next).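

In this assay the change to 4-(trifluoromethyl)phenyl in place of methyl on a carbonyl carbon gives a 1.7-fold higher number from compound 2 to compound 3 (0.23 log units; within the scatter) and leaves the two compounds unordered. Among the compounds shown here, this is the first single-place comparison at this position: an aromatic ring enters where one carbon stood, with no gap beyond the scatter. Nothing given here accounts for this result. From the compounds shown here alone, whether an amine or a longer alkyl chain on this carbonyl carbon would separate from compound 2 remains open, and this single pair cannot show how other groups at this position would behave.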